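The source may report more compounds than this note shows. Statements on the series, on what has been measured and on what is new or still open speak of the compounds shown alone.

Working notes on the series.

Of the compounds shown here, two have been measured so far in a functional assay on MIA PaCa-2 cells (Homo sapiens) for inhibition, read by MTT assay, with a stated time of 72 h; on this read-out higher numbers stand for weaker inhibition of growth and lower numbers for stronger inhibition of growth. Compound 1 `Cc1ccc(C)c(S(=O)(=O)NCCCCCCNCc2ccc(Br)cc2)c1` stands at the higher of the two numbers: in this assay compound 1 gives 12000 nM. For the measured compounds named here, its only neighbour on the table is compound 2 `COc1cccc(CNCCCNS(=O)(=O)c2cc(C(F)(F)F)cc(C(F)(F)F)c2)c1`, which in this assay gives 3400 nM; the gap between the two lies beyond the scatter of the measurement, so compound 1 is the weaker of the pair. Going by the values given here, no two measured compounds differ in one place only, so no single structural step has yet been put to the numbers.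

Compound 3 `O=S(=O)(NCCCCCCNCc1ccc(Br)cc1)c1ccc2c(c1)OCC2` is the next candidate and has not yet been measured in this assay. Relative to compound 1 it carries a group of 9 heavy atoms (8 carbon, 1 oxygen; one five-membered non-aromatic ring with 1 hetero atom, one six-membered aromatic ring of carbon only) in place of a group of 8 heavy atoms (8 carbon; one six-membered aromatic ring of carbon only), on a sulfonyl sulfur. Among the compounds with values here, no measured step tells what such a change does here, so the expectation rests on compound 1 alone and on a change of this modest size. In this assay the step is estimated as a 1.2-fold lower number from compound 1 to compound 3 (0.08 log units; within the scatter), that is, no shift beyond the scatter in either direction. Compound 3 is therefore expected to give 10000 nM in this assay, with a plausible range from 4000 nM to 25000 nM.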

Compound 3, concentration for 50% growth inhibition: 13000 nM
Compound 3: the middle estimate sits 1.3-fold (0.11 log units) below what was measured, and the stated range covers the measured number.
By their numbers in this assay, from the lowest: compound 2; then compounds 1 and 3 (each within the scatter of the next).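

On the sulfonyl sulfur whose other neighbour is the sulfonamide nitrogen, the series now has its first step that differs in one place: in this assay the group entering in place of 2,5-dimethylphenyl gives a 1.1-fold higher number from compound 1 to compound 3 (0.03 log units; within the scatter) and so leaves the number within the scatter. For this one pair, the added oxygen, the five-membered non-aromatic ring and the hydrogen-bond acceptor that come with the new group go with no shift that can be told from the scatter, in either direction. Nothing available bears on why the two groups read alike.

Compound 2 differs from compound 1 and compound 3 in more than one place, so its lower number cannot be assigned to any single part of its structure, and whether the sulfonyl group, the chain or the benzyl group carries the difference remains unresolved. Also open, on these data alone, is whether a group of another kind on the same sulfonyl sulfur, such as a phenyl ring bearing a carboxylic acid or an amine, would move the number beyond the scatter, and whether a shorter chain would do so with the group of compound 3 held in place.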